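Aryl variation at the ring-oxygen position of the core

This account rests on a few compounds, and the source may have more. Where it says the series, first, only, none or still open, it means among the compounds named here.

Measured so far:
compound 1 `CCC1=C(O)c2c(oc(-c3ccccc3C)cc2=O)C(CC)(CC)C1=O` — 40.9 uM
compound 2 `CCC1=C(O)c2c(oc(-c3ccc(C)c(F)c3)cc2=O)C(CC)(CC)C1=O` — 28.1 uM

Both compounds were tested in a functional assay on KB cells (Homo sapiens) for antiproliferative activity, read by sulforhodamine B assay, with a stated time of 3 days; a lower number here means that less compound is needed, a higher number that more compound is needed for the effect. Within the data shown here, compound 2 gives the lowest of the two numbers, and the only measured step, a 1.5-fold lower number from compound 1 to compound 2 (0.16 log units; within the scatter), lies within the scatter, so compound 1 and compound 2 cannot be told apart on these numbers.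

Compound 3 `CCC1=C(O)c2c(oc(-c3cc(C)cc(C)c3)cc2=O)C(CC)(CC)C1=O` has not been measured. Its change from compound 2 is 3,5-dimethylphenyl in place of 3-fluoro-4-methylphenyl on an aromatic carbon. Among the measured compounds shown here, the one measured step, the exchange of aryl groups from compound 1 to compound 2, is the only comparison that bears on a swap of this kind, and it produced no movement beyond the scatter. For the measured compounds named here, no step here therefore supports any change beyond the scatter in this assay for compound 3, and the estimated step is a 1.1-fold higher number from compound 2 to compound 3 (0.03 log units; within the scatter). For compound 3 the estimated value in this assay is 30 uM, with a range of 12 uM to 75 uM.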

Compound 3, concentration for half-maximal effect: 45.5 uM
The estimate for compound 3 lay 1.5-fold (0.18 log units) below the measured number; the range from low to high includes it.
By their numbers in this assay, from the lowest: compounds 2, 1 and 3 (each within the scatter of the next).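

In this assay, among these compounds, a third aryl group at this position again gives no step that stands out from the scatter: a 1.6-fold higher number from compound 2 to compound 3 (0.21 log units; within the scatter), and a 1.1-fold higher number from compound 1 to compound 3 (0.05 log units; within the scatter). The exchange of 3-fluoro-4-methylphenyl for 3,5-dimethylphenyl removes the only fluorine among these aryl groups while the group keeps its heavy-atom count, and the number stays within the scatter, so these three aryl groups cannot be told apart on these data. No supporting measurement is available to explain these numbers.

Going by these compounds, whether an aryl group carrying an amine or a carboxylic acid, or a longer chain in place of a methyl group, would move the number beyond the scatter remains open. Also open, on these data alone, is how changes elsewhere on the shared core, which is the same in compound 1, compound 2 and compound 3, would read in this assay.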